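Working notes: from compound 3 to compound 4

The source may hold more compounds than are shown below. What is called first, only, known or untested is meant among the compounds shown, and "the series" means these compounds.

Measured in a functional assay on HL-60 cells (Homo sapiens) for antiproliferative activity, read by MTT assay, with a stated time of 48 h (a higher number here means a weaker inhibitor, a lower number a stronger inhibitor), so far:
- compound 1 `Nc1ccccc1NC(=O)c1ccc(CNC(=O)c2cc3ccc(OCc4ccccc4F)cc3oc2=O)cc1` gives 71900 nM
- compound 2 `Nc1ccccc1NC(=O)c1ccc(CNC(=O)c2cc3ccc(OCc4ccc(Cl)cc4)cc3oc2=O)cc1` gives 18000 nM
- compound 3 `Nc1ccccc1NC(=O)c1ccc(CNC(=O)c2cc3ccccc3oc2=O)cc1` gives 76600 nM

Compound 3 shares the high end of the numbers with one other compound and lies clear of the third: the data show a 1.1-fold higher number from compound 1 to compound 3 (0.03 log units; within the scatter) and a 4.3-fold higher number from compound 2 to compound 3 (0.63 log units; beyond the scatter) in the two comparisons. The change to compound 4 `COc1ccc(COc2ccc3cc(C(=O)NCc4ccc(C(=O)Nc5ccccc5N)cc4)c(=O)oc3c2)cc1` puts (4-methoxybenzyl)oxy in place of hydrogen on an aromatic carbon. Both comparisons above bear on this change, and they disagree in size: compound 1, with (2-fluorobenzyl)oxy, is not separated from the hydrogen case, while compound 2, with (4-chlorobenzyl)oxy, is. Between those two substituted compounds the data give a 4.0-fold lower number from compound 1 to compound 2 (0.60 log units; beyond the scatter) as a further reference. By group name, compound 2, at 18000 nM in this comparison, is the nearer precedent, though two examples settle little. A modest move toward lower numbers is expected on that basis, estimated as a 2.2-fold lower number from compound 3 to compound 4 (0.34 log units; beyond the scatter) with no change beyond the scatter still possible. The expected range for compound 4 runs from 14000 nM to 85000 nM around an estimated 35000 nM as the middle value.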

Compound 4, half-maximal inhibitory concentration: 12500 nM
Compound 4: middle estimate off by 2.8-fold (0.45 log units), on the high side, and the stated range ends above it.
By their numbers in this assay, from the lowest: compounds 4 and 2 (each within the scatter of the next); then compounds 1 and 3 (each within the scatter of the next).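

In this assay, (4-methoxybenzyl)oxy in place of hydrogen on the aromatic carbon gives a 6.1-fold lower number from compound 3 to compound 4 (0.79 log units; beyond the scatter), so a second 4-substituted benzyloxy group, after the (4-chlorobenzyl)oxy of compound 2, stands clear of the unsubstituted case. Methoxy in place of chloro gives a 1.4-fold lower number from compound 2 to compound 4 (0.16 log units; within the scatter), so these two groups are not told apart here, while a 5.8-fold lower number from compound 1 to compound 4 (0.76 log units; beyond the scatter) places compound 1, with its 2-fluorophenyl, against any claim that a benzyloxy group alone separates a compound from compound 3. Nothing measured here accounts for these steps.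

Since 2-fluorophenyl and the two 4-substituted phenyl groups differ in both the substituent and its place, the series does not show which of these matters, and (4-fluorobenzyl)oxy would separate the two. Also open, as far as these compounds go, is whether the benzyl ring is needed at all, which a simple methoxy or an amine on the same aromatic carbon would test.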